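Selenium-to-sulfur swap in the bis-thiophene imidoyl series

A few compounds are considered here, and "the series" means these few. Any claim that something is new, unique, unknown or untested is made for them only; others in the source may bear on it.

Compound 1 `C[Se]/C(=N\C(=O)c1cccs1)NC(=O)c1cccs1` is one of three measured members of the series. In an ADME assay on MCF-10A cells (Homo sapiens) for cytotoxicity, read by MTT assay, with a stated time of 72 h (a higher number here means a weaker inhibitor of growth, a lower number a stronger inhibitor of growth), compound 1 gives 9260 nM, the second highest of the three numbers: compound 2 `O=C(/N=C(/NC(=O)c1csc([N+](=O)[O-])c1)[Se]Cc1ccccc1)c1csc([N+](=O)[O-])c1` gives 24400 nM, a higher number beyond the scatter, while compound 3 `C[Se]/C(=N\C(=O)c1ccno1)NC(=O)c1ccno1` gives 2890 nM, the lowest of the three, also beyond the scatter from compound 1. Compound 4 `CS/C(=N\C(=O)c1cccs1)NC(=O)c1cccs1` differs from compound 1 in one place: a group of 2 heavy atoms (1 carbon, 1 sulfur; no ring) in place of a group of 2 heavy atoms (1 carbon, 1 selenium; no ring), on a carbon with a double bond to nitrogen. Within the data shown here, no measured pair shows this change, so its size is unknown from these data. In this assay the expected step for compound 4 is a 1.9-fold higher number from compound 1 to compound 4 (0.29 log units; within the scatter), toward a higher number, of a size that may not exceed the scatter. Compound 4 is estimated at 18000 nM, within a range from 6000 nM to 50000 nM.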

Compound 4, concentration for 50% growth inhibition: 19700 nM
Compound 4: middle estimate off by 1.1-fold (0.04 log units), on the low side; the range from low to high includes it.
By their numbers in this assay, from the lowest: compound 3; then compound 1; then compounds 4 and 2 (each within the scatter of the next).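

In this assay, among these compounds, the methylsulfanyl group in place of the selenium-bearing group, on a carbon with a double bond to nitrogen, gives a 2.1-fold higher number from compound 1 to compound 4 (0.33 log units; beyond the scatter) as the first direct reading of this change. The step is modest but beyond the scatter, so this position responds to the swap, and compound 1 is the stronger inhibitor of growth of the pair. Nothing available accounts for the step. Still open, as far as these compounds go, is whether the same swap gives a similar step on the core of compound 3. From the compounds shown here alone, how an amine or a longer chain would read at this place is also open.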